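Chloro to fluoro on the pendant phenyl: expected outcome

The source may report more compounds than this note shows. Statements on the series, on what has been measured and on what is new or still open speak of the compounds shown alone.

The series shares one core, with the pendant aryl group varied. Compound 1 `CCOC(=O)C1=CC(c2ccccc2)C2=C(CC(C)(C)CC2=O)N1` is reported in an assay on isolated protein for inhibition of glucose-6-phosphatase catalytic subunit 1 (Homo sapiens), read by inositol phosphate accumulation, with a stated time of 30 min, tested at 100 uM (a lower number here means less inhibition, a higher number more inhibition at the concentration tested (going by the name of the read-out)), as "not active" (no number reported), a statement given without a number. Among the compounds with values here, compound 2 `CC1(C)CC(=O)C2=C(C1)NC(c1ccccc1)=CC2c1ccc(Cl)cc1` gives in this assay a read-out of 7.16%, the only number in hand for the series; compound 2 therefore stands as the sole quantified point, a low level of inhibition with nothing to rank it against apart from the unnumbered entry for compound 1. Compound 3 `CC1(C)CC(=O)C2=C(C1)NC(c1ccccc1)=CC2c1ccc(F)cc1` remains to be measured in this assay. It differs from compound 2 in one place: fluoro in place of chloro on an aromatic carbon. Within the data shown here, no step between two measured compounds is available for a change of this kind, so there is no measured guide to its size. The expected step of a number 1.2 percentage points lower from compound 2 to compound 3 (within the scatter) is none beyond the scatter, in no particular direction. Compound 3 is accordingly estimated at 6%, with a range from 0% to 18%. A report without a number, as for compound 1, is also a real possibility.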

Compound 3, a percentage reported as inhibition, at one concentration (the size of the read-out at that concentration, not a potency): 7.38%
The estimate for compound 3 lay 1.4 percentage points below the measured number, within the range that was stated.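

In this assay, within the data shown here, fluoro in place of chloro on the aromatic carbon gives a number 0.2 percentage points higher from compound 2 to compound 3 (within the scatter), the first measured step at this place. The 4-chlorophenyl and 4-fluorophenyl compounds cannot be told apart in this read-out, and both show only a low level of inhibition at the single concentration tested, so compound 2 no longer stands as a lone number, and this exchange of one halogen for the other does not separate the pair. No measurement at hand bears on why the two halogens read alike.

Still open, going by these compounds, is whether a group of a different kind at this place, such as an amine, a carboxylic acid or a methoxy group, would give a read-out beyond the scatter, as the numbered compounds cover only chloro and fluoro. Also open, on these data alone, is what the rest of the shared core contributes, as compound 1 differs from compound 2 in more than one place and its entry without a number gives no readable step.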